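From 4-fluorobenzyl to (piperidin-4-yl)methyl

The source may report more compounds than this note shows. Statements on the series, on what has been measured and on what is new or still open speak of the compounds shown alone.

In a physicochemical assay for solubility, using the shake flask method, in simulated intestinal fluid, measured as kinetic solubility, with a stated time of 2 h, at 25 degrees C, at pH 6.5 (on this read-out higher numbers stand for higher solubility and lower numbers for lower solubility), compound 2 `Cc1noc(-c2nc(C)c3c(c2N)C(=O)N(Cc2ccc(F)cc2)C3=O)n1` gives < 5000 nM, which is a limit of the assay and not a number. Compound 1 `Cc1noc(-c2nc(C)c3c(c2N)C(=O)N(Cc2ccccc2)C3=O)n1` gives < 5000 nM, also a limit. Compound 3 `Cc1noc(-c2nc(C)c3c(c2N)C(=O)N(Cc2ccc(-n4cccn4)cc2)C3=O)n1` gives < 5000 nM, again a limit. Every reading so far therefore rests on one mark: the limit of < 5000 nM in this assay, at which 3 of the 3 values shown sit. Compound 4 `Cc1noc(-c2nc(C)c3c(c2N)C(=O)N(CC2CCNCC2)C3=O)n1` departs from compound 2 by this change: piperidin-4-yl in place of 4-fluorophenyl on a saturated chain carbon bound to an amide-type nitrogen in a ring. The closest measured changes are a step that the two limits leave unreadable from compound 1 to compound 2 and a step that the two limits leave unreadable from compound 2 to compound 3; both keep the aromatic ring and neither gives a size to carry over. Compound 4 replaces that ring itself, so a rise is expected from the structural change alone, with a wide margin. The expected change is an at least 8.0-fold higher number from compound 2 to compound 4 (0.90 log units; beyond the scatter). Compound 4 is estimated at 40000 nM, within a range of 4000 nM to 200000 nM.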

Compound 4, solubility: 160000 nM
The estimate for compound 4 lay 4.0-fold (0.60 log units) below the measured number; the range from low to high includes it.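

On a saturated chain carbon bound to an amide-type nitrogen in a ring, piperidin-4-yl in place of 4-fluorophenyl gives, in this assay, an at least 32-fold higher number from compound 2 to compound 4 (1.50 log units; beyond the scatter), and piperidin-4-yl in place of phenyl gives an at least 32-fold higher number from compound 1 to compound 4 (1.50 log units; beyond the scatter). Going by these compounds alone, these are the only readable steps at this position, and the steps among compound 1, compound 2 and compound 3 cannot be read. Those compounds could show no size because they all rest on one mark: the limit of < 5000 nM in this assay, at which 3 of the 4 values shown sit.

Going by these compounds, whether the step follows the nitrogen of piperidin-4-yl or the loss of the aromatic ring stays open. A cyclohexyl group at this place would separate the two.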